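Methyl in place of methoxy: what compound 3 might show

This account rests on a few compounds, and the source may have more. Where it says the series, first, only, none or still open, it means among the compounds named here.

Compound 1, `COC(=O)c1c(Nc2ccccc2)sc(C(=O)c2ccc(OC)cc2)c1C`: 48.1%
Compound 2, `COC(=O)c1c(Nc2ccc(Cl)cc2)sc(C(=O)c2ccc(OC)cc2)c1C`: "not active" (no number reported)

Within the data shown here, in a functional assay, with a stated time of 150 min, tested at 30 ug/mL (on this read-out higher numbers stand for a stronger effect at the one concentration tested and lower numbers for a weaker effect), compound 1 gives 48.1%, and this is the only number available, since compound 2 carries no figure. Compound 3, `COC(=O)c1c(Nc2ccccc2)sc(C(=O)c2ccc(C)cc2)c1C`, differs from compound 1 in one place: methyl in place of methoxy on an aromatic carbon. Among the measured compounds shown here, no measured step between two compounds exists here, so the size of this change cannot be read from the data. In this assay a step no larger than the usual scatter is expected, if anything slightly downward. Compound 3 is therefore estimated at 40%, within 15% to 60%. The expected step is a number 8.1 percentage points lower from compound 1 to compound 3 (within the scatter).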

Compound 3, a percentage reported as activity, at one concentration (the size of the read-out at that concentration, not a potency): 9.35%
Compound 3: the middle estimate sits 30.7 percentage points above what was measured; measured number outside the range, below it.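

In this assay, changing 4-methoxyphenyl to 4-methylphenyl gives a number 38.8 percentage points lower from compound 1 to compound 3 (beyond the scatter). Among these compounds, this is the first measured step, and it shows that the group at this place on the ring strongly affects the read-out, at least in this one pair. No supporting measurement is available to explain the drop. As far as these compounds go, it remains open whether the oxygen itself or the whole methoxy group matters. A hydroxyl, an ethoxy or a dimethylamino group at the same place would help separate these possibilities.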